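The source may hold more compounds than are shown below. What is called first, only, known or untested is meant among the compounds shown, and "the series" means these compounds.

Compound 1 `Cc1ccc2c(c1)/C(=N/NC(=S)N1CCN(c3ccccc3)CC1)C(=O)N2` gives 9880 nM in a functional assay on A549 cells (Homo sapiens) for inhibition, read by MTT assay, with a stated time of 72 h; on this read-out higher numbers stand for weaker inhibition and lower numbers for stronger inhibition. Compound 2 `O=C1Nc2ccc(Cl)cc2/C1=N/NC(=S)N1CCN(c2ccccc2)CC1` gives 7340 nM in this assay, and compound 3 `O=C1Nc2cccc(Br)c2/C1=N/NC(=S)N1CCN(c2ccccc2)CC1` gives 54000 nM. Compound 2 has the lowest of the three numbers, but its gap to compound 1 stays within the scatter, as the step of a 1.3-fold lower number from compound 1 to compound 2 (0.13 log units; within the scatter) shows; only its gap to compound 3 lies beyond the scatter. Compound 4 `O=C1Nc2ccc(Cl)cc2/C1=N/NC(=S)N1CCN(c2ccc(F)cc2F)CC1` differs from compound 2 by 2,4-difluorophenyl in place of phenyl on an amine nitrogen in a ring. Among the compounds with values here, none of the measured steps touches this part of the shared core: the single-change step a 1.3-fold lower number from compound 1 to compound 2 (0.13 log units; within the scatter) concerns a substituent on the core, and the difference between compound 2 and compound 3 does as well. The measured data therefore give no direct guide for this change, and no step beyond the scatter is expected in this assay. Compound 4 is estimated at 7000 nM, with a range from 2500 nM to 20000 nM. This estimate means an expected step of a 1.0-fold lower number from compound 2 to compound 4 (0.02 log units; within the scatter).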

Compound 4, half-maximal inhibitory concentration: 11400 nM
Beside the measured number, compound 4's estimate is 1.6-fold (0.21 log units) below it; measured number inside the range.
By their numbers in this assay, from the lowest: compounds 2, 1 and 4 (each within the scatter of the next); then compound 3.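

Within the data shown here, the first measured change at this position, on the amine nitrogen of the six-membered ring, is 2,4-difluorophenyl in place of phenyl, and in this assay it gives a 1.6-fold higher number from compound 2 to compound 4 (0.19 log units; within the scatter). The two added fluorine atoms on the phenyl ring therefore produce no step beyond the scatter, unlike the gap seen earlier between compound 2 and compound 3, which differ elsewhere on the shared core. No measurement shown gives a reason for this result.

The compounds shown leave open whether a single fluorine on the phenyl ring, or a benzyl, pyridine or methyl group on this nitrogen, would also stay within the scatter of compound 2. They also leave open whether 2,4-difluorophenyl would give a similar step with the methyl or bromo substituent of compound 1 or compound 3.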